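A few compounds are considered here, and "the series" means these few. Any claim that something is new, unique, unknown or untested is made for them only; others in the source may bear on it.

In a functional assay on T47D cells (Homo sapiens) for cytotoxicity, read by CCK-8 assay (a higher number here means a weaker inhibitor, a lower number a stronger inhibitor), the compounds measured so far stand as follows:

Compound 1, `Oc1ccc(-c2cc(-c3cccs3)cc(-c3cccc(O)c3)n2)cc1`, gives 780 nM.
Compound 2, `Oc1ccc(-c2cc(-c3cccnc3)cc(-c3ccccc3O)n2)cc1`, gives > 50000 nM, which is a limit of the assay and not a number.
Compound 3, `Oc1cccc(-c2cc(-c3cccnc3)cc(-c3cccc(O)c3)n2)c1`, gives > 50000 nM, again a limit of the assay rather than a number.

Compound 3 therefore stands at the inactive end of what has been seen, and it is not alone there: the limit of > 50000 nM in this assay, at which 2 of the 3 values shown sit. For the measured compounds named here, only compound 1 returns a number, and it is the one compound in the set that carries a thienyl group in place of the pyridin-3-yl group of the other two; no step between it and the others is counted here, so only the two values are compared.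

Compound 4, `Oc1ccc(-c2cc(-c3cccnc3)cc(-c3cccc(O)c3)n2)cc1`, arises from compound 3 by a change in one place: 4-hydroxyphenyl in place of 3-hydroxyphenyl on an aromatic carbon. Compound 4 thus pairs a 4-hydroxyphenyl with a 3-hydroxyphenyl, as compound 1 does, while keeping the pyridin-3-yl group of compound 3.

Both pyridin-3-yl compounds sit at the limit, so the expectation for compound 4 is a weak value, with a fair chance that it is again reported only as a limit. Compound 4 is estimated at 20000 nM, within 3000 nM to 100000 nM. The expected step of an at least 2.5-fold lower number from compound 3 to compound 4 (0.39 log units; beyond the scatter) is therefore a move toward potency whose size is uncertain, because compound 3 gives only > 50000 nM.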

Compound 4, half-maximal inhibitory concentration: > 50000 nM
Compound 4 ended at the assay's limit (the forecaster's own chance of this, stated with the estimate: 50%); at least 2.5-fold (0.39 log units) between middle value and limit.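

In this assay, for the compounds shown here, the first readable comparison in one place is at the group that differs between compound 1 and compound 4: pyridin-3-yl in place of thiophen-2-yl on an aromatic carbon gives an at least 64-fold higher number from compound 1 to compound 4 (1.80 log units; beyond the scatter), with the 4-hydroxyphenyl and 3-hydroxyphenyl groups the same in both. The 4-hydroxyphenyl and 3-hydroxyphenyl pairing therefore does not by itself give a measurable value in this assay, and with pyridin-3-yl present neither the change from 3-hydroxyphenyl to 4-hydroxyphenyl next to the ring nitrogen nor the change from 2-hydroxyphenyl to 3-hydroxyphenyl can be read, as both ends of each step are limits. All three pyridin-3-yl compounds now sit at that limit, which is a limit of the assay and not a number: the limit of > 50000 nM in this assay, at which 3 of the 4 values shown sit.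

The compounds shown leave open whether the hydroxyphenyl positions matter at all once thiophen-2-yl is present, as compound 1 is the only thiophen-2-yl compound here. They also leave open whether the step belongs to pyridin-3-yl in particular or would also appear with a plain phenyl, a furan-2-yl or an aminomethyl group at that carbon.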